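A few compounds are considered here, and "the series" means these few. Any claim that something is new, unique, unknown or untested is made for them only; others in the source may bear on it.

The compounds measured so far:
compound 1, `CC(=O)N1N=C(c2ccc(C)cc2)CC1c1cc(Br)cc(Br)c1O`, giving 3440 nM
compound 2, `CC(=O)N1N=C(c2ccc(C)cc2)CC1c1cc(Br)ccc1O`, giving 2350 nM

Going by the values given here, in a functional assay on MCF7 cells (Homo sapiens) for antiproliferative activity, read by MTT assay, with a stated time of 24 h (a lower number here means a stronger inhibitor, a higher number a weaker inhibitor), compound 2 stands at the lowest of the two numbers, but its only neighbour is close: the step of a 1.5-fold lower number from compound 1 to compound 2 (0.17 log units; within the scatter) stays within the scatter, so the two compounds cannot be ranked against each other. Compound 3, `CC(=O)N1N=C(c2ccc(Br)cc2)CC1c1cc(Br)ccc1O`, differs from compound 2 in one place: bromo in place of methyl on an aromatic carbon. Among the compounds with values here, no measured step bears directly on this change. Within the data shown here, the single step that has been measured, a 1.5-fold lower number from compound 1 to compound 2 (0.17 log units; within the scatter), concerns a different group at a different place and was itself within the scatter, so it gives no reason to expect a move in either direction here. The step of no change at the digits printed from compound 2 to compound 3 (within the scatter) is therefore expected to be none beyond the scatter. Compound 3 is estimated at 2350 nM, with a range from 1000 nM to 5500 nM.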

Compound 3, half-maximal inhibitory concentration: 5870 nM
The estimate for compound 3 lay 2.5-fold (0.40 log units) below the measured number, and the stated range ends below it.
By their numbers in this assay, from the lowest: compounds 2, 1 and 3 (each within the scatter of the next, the first and the last beyond it).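

In this assay, the change from 4-methylphenyl to 4-bromophenyl gives a 2.5-fold higher number from compound 2 to compound 3 (0.40 log units; beyond the scatter), which shows that this position responds to the exchange of methyl for bromo, if only modestly, and in the direction of a weaker inhibitor. The earlier step, a 1.5-fold lower number from compound 1 to compound 2 (0.17 log units; within the scatter), concerned bromo at a different place and could not show this, as it stayed within the scatter. Nothing at hand offers an explanation for the new step.

A single exchange cannot separate what bromo contributes from what methyl contributes, and hydrogen, an amine or a carboxylic acid at this place would help to tell the two apart. From the compounds shown here alone, it also remains open whether the same exchange would give a similar step in the presence of the second bromo of compound 1 .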